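From a benzoyl to a 2-chlorophenyl on the sulfur chain

A few compounds are considered here, and "the series" means these few. Any claim that something is new, unique, unknown or untested is made for them only; others in the source may bear on it.

Of the compounds shown here, three sharing one core have been tested in a functional assay on A549 cells (Homo sapiens) for cytotoxicity, read by MTT assay, with a stated time of 48 h (on this read-out lower numbers stand for stronger inhibition and higher numbers for weaker inhibition), and none of them gave a number. Compound 1 `CCOC(=O)CSc1nnc(C)n1N1C(=O)c2ccccc2C1=O` stays at a limit of the assay, > 200000 nM. Compound 2 `Cc1ccc(C(=O)CSc2nnc(C)n2N2C(=O)c3ccccc3C2=O)cc1` likewise reaches only a limit, > 200000 nM. Compound 3 `Cc1nnc(SCC(=O)c2ccccc2)n1N1C(=O)c2ccccc2C1=O` also sits at a limit, > 200000 nM. The steps among them, a step that the two limits leave unreadable from compound 1 to compound 2, a step that the two limits leave unreadable from compound 1 to compound 3 and a step that the two limits leave unreadable from compound 2 to compound 3, therefore cannot be sized; all that can be said is the limit of > 200000 nM in this assay, at which 3 of the 3 values shown sit. Compound 3 thus stands nowhere readable on the numbers shown: it is simply one of three limits.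

Compound 4 `Cc1nnc(SCc2ccccc2Cl)n1N1C(=O)c2ccccc2C1=O` differs from compound 3 by 2-chlorophenyl in place of benzoyl on a saturated chain carbon bound to a sulfur. For the measured compounds named here, no measured step bears on this change, since every step at hand joins two limits and stays unreadable. The expected step that the limit leaves unreadable from compound 3 to compound 4 is accordingly no more than a guess that compound 4 will behave like its three relatives and most probably also stop at a limit of this assay, in neither direction beyond the scatter. Compound 4 is estimated at 250000 nM, with a range from 60000 nM to 1000000 nM.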

Compound 4, half-maximal inhibitory concentration: > 200000 nM
Compound 4 was reported as a limit (the forecaster's own chance of this, stated with the estimate: 80%); the middle value lies beyond the limit too.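

Compound 4 also stops at a limit, > 200000 nM in this assay as well. Its steps to compound 1, compound 2 and compound 3 therefore cannot be read, and all that stands is this: the limit of > 200000 nM in this assay, at which 4 of the 4 values shown sit. The compounds shown leave open whether any group on the sulfur chain of the shared core gives a readable value in this assay at all.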